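Adding a methyl to the saturated ring of compound 3

The source may hold more compounds than are shown below. What is called first, only, known or untested is meant among the compounds shown, and "the series" means these compounds.

Of the compounds shown here, three sharing one core have been tested in a functional assay on U-87MG ATCC cells (Homo sapiens) for inhibition, read by MTT assay, with a stated time of 72 h; a higher number here means a weaker inhibitor, a lower number a stronger inhibitor. Compound 1 `COc1cc2c(Oc3ccc(NC(=O)c4nn(-c5ccccc5C)c(=O)cc4C)cc3F)ccnc2cc1OCCCN1CCC(C)CC1` gives 2240 nM. Going by the values given here, compound 2 `COc1cc2c(Oc3ccc(NC(=O)c4nn(-c5ccccc5OC(F)(F)F)c(=O)cc4C)cc3F)ccnc2cc1OCCCN1CCC(C)CC1` gives 800 nM, and the only single-point step among them, a 2.8-fold lower number from compound 1 to compound 2 (0.45 log units; beyond the scatter), concerns a substituent on an aromatic carbon. Compound 3 `COc1cc2c(Oc3ccc(NC(=O)c4nn(-c5ccc(Cl)cc5)c(=O)cc4C)cc3F)ccnc2cc1OCCCN1CCCCC1` gives 1400 nM; among the three numbers it is the second highest, and its gaps to compound 1 and to compound 2 both lie within the scatter of this assay, so no order among these three can be claimed.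

Compound 4 `COc1cc2c(Oc3ccc(NC(=O)c4nn(-c5ccc(Cl)cc5)c(=O)cc4C)cc3F)ccnc2cc1OCCCN1CCC(C)CC1` is not yet measured. It differs from compound 3 in one place: methyl in place of hydrogen on a saturated ring carbon. Cut one bond further out, the change reads piperidin-1-yl to 4-methylpiperidin-1-yl, the group that compound 1 and compound 2 already carry.

Among the compounds with values here, no measured pair isolates this change: the step from compound 1 to compound 2 alters a different part of the molecule and says nothing about a methyl on the saturated ring. With nothing to lean on, the expectation for compound 4 in this assay is a step of no change at the digits printed from compound 3 to compound 4 (within the scatter), that is, none beyond the scatter. Compound 4 is therefore estimated at 1400 nM, within a range of 600 nM to 3200 nM.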

Compound 4, half-maximal inhibitory concentration: 1350 nM
Compound 4: the middle estimate sits 1.0-fold (0.02 log units) above what was measured; the measured number falls inside the stated range.
By their numbers in this assay, from the lowest: compounds 2, 4, 3 and 1 (each within the scatter of the next, the first and the last beyond it).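

In this assay, going by these compounds alone, methyl in place of hydrogen on a saturated ring carbon, three ring bonds from the ring nitrogen, gives a 1.0-fold lower number from compound 3 to compound 4 (0.02 log units; within the scatter), the first direct reading of this position, and at this resolution piperidin-1-yl and 4-methylpiperidin-1-yl cannot be told apart when 4-chlorophenyl sits on the aromatic nitrogen. With 4-methylpiperidin-1-yl held constant, the group on the aromatic nitrogen can now be compared more widely: 4-chlorophenyl in place of 2-(trifluoromethoxy)phenyl gives a 1.7-fold higher number from compound 2 to compound 4 (0.23 log units; within the scatter), and 4-chlorophenyl in place of 2-methylphenyl gives a 1.7-fold lower number from compound 1 to compound 4 (0.22 log units; within the scatter), so compound 4 can be separated from neither of the two compounds that share its saturated ring. No supporting data are available to explain these results.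

The compounds shown carry only hydrogen or methyl at this ring carbon, so it remains open whether a hydroxyl, a primary amine, a carboxylic acid or a longer chain such as n-butyl would also leave the number within the scatter. As far as these compounds go, it is also open whether methyl would give the same result alongside 2-methylphenyl or 2-(trifluoromethoxy)phenyl, since neither group appears here with the unsubstituted piperidin-1-yl.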